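Fluoro in Place of Trifluoromethyl on the Aryl Group

The compounds below may be only part of what the source reports. "The series", "measured", "known", "first", "only" and "open" are said of these compounds alone.

Measured compounds:
compound 1 `Nc1scc(CN2CCN(c3ccccc3C(F)(F)F)CC2)c1C(=O)c1ccc(Cl)cc1`: 0%
compound 2 `Nc1scc(CN2CCN(c3ccc(C(F)(F)F)cc3)CC2)c1C(=O)c1cccc(C(F)(F)F)c1`: 0%

In an assay on CHO cells for displacement of a labelled ligand from adenosine receptor A1 (Homo sapiens), read by scintillation counting, with a stated time of 120 min, tested at 10 uM (on this read-out higher numbers stand for more inhibition at the one concentration tested (going by the name of the read-out) and lower numbers for less inhibition), compound 1 gives 0%, and compound 2 gives 0%. Compound 1 stands level with compound 2 at the digits shown, a gap within the usual scatter; neither compound shows measurable inhibition. Compound 3 `Nc1scc(CN2CCN(c3ccccc3F)CC2)c1C(=O)c1ccc(Cl)cc1` differs from compound 1 by fluoro in place of trifluoromethyl on an aromatic carbon. Going by the values given here, no step between two measured compounds exists here, so the data give no guide to the effect of this change. A step of no change at the digits printed from compound 1 to compound 3 (within the scatter) is expected, none beyond the scatter. The expected value for compound 3 is 0%, with a range from -10% to 12%.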

Compound 3, a percentage reported as inhibition, at one concentration (the size of the read-out at that concentration, not a potency): 4%
Compound 3: middle estimate off by 4 percentage points, on the low side; the range from low to high includes it.
By their numbers in this assay, from the lowest: compounds 1, 2 and 3 (each within the scatter of the next).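

Placing fluoro in place of trifluoromethyl on this aromatic carbon gives, in this assay, a number 4 percentage points higher from compound 1 to compound 3 (within the scatter). This position has now been varied directly, and the smaller group brings no inhibition that stands clear of the scatter at the one concentration tested. No measurement at hand offers an explanation for this result.

As far as these compounds go, whether an amine or a methoxy group on this carbon would give clear inhibition remains open. So does whether fluoro would give the same result on a compound that shows clear inhibition.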